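This account rests on a few compounds, and the source may have more. Where it says the series, first, only, none or still open, it means among the compounds named here.

Measured so far:
compound 1 `COc1ccc(COc2ccc(OCCOCCNC3CCCC3)cc2)cc1` with 15700 nM
compound 2 `c1ccc(COc2ccc(OCCOCCNC3CCOC3)cc2)cc1` with 48000 nM

Both numbers come from a functional assay on SK-OV-3 cells (Homo sapiens) for inhibition, read by CCK-8 assay, with a stated time of 70 h; on this read-out higher numbers stand for weaker inhibition and lower numbers for stronger inhibition. Compound 1 holds the lower of the two; compound 2 sits higher, and the gap between them is wider than the usual scatter. Among the measured compounds shown here, no single-point step connects these two compounds, so nothing more is read from them than what the two values show.

Compound 3 `CCOc1ccc(OCCOCCNC2CCCC2)cc1` has not been measured. It differs from compound 1 in one place: methyl in place of 4-methoxyphenyl on a saturated chain carbon bound to an oxygen on an aromatic ring. The change strips away most of the outer part of the chain and leaves a short ethyl group in its stead.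

For the measured compounds named here, with no measured step of this kind to lean on, the step from compound 1 to compound 3 is expected to raise the number beyond the scatter, by about a 2.9-fold higher number from compound 1 to compound 3 (0.46 log units; beyond the scatter). Compound 3 is therefore estimated at 45000 nM, with a range from 15000 nM to 130000 nM.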

Compound 3, half-maximal inhibitory concentration: 90500 nM
Beside the measured number, compound 3's estimate is 2.0-fold (0.30 log units) below it; the measured number falls inside the stated range.
By their numbers in this assay, from the lowest: compound 1; then compounds 2 and 3 (each within the scatter of the next).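

In this assay, among the compounds shown here, the single change at this position, methyl in place of 4-methoxyphenyl on a saturated chain carbon bound to an oxygen on an aromatic ring, gives a 5.8-fold higher number from compound 1 to compound 3 (0.76 log units; beyond the scatter). For the compounds shown here, this is the first direct reading of this position, which compounds 1 and 2 could not give, as no single step joined them. It shows that, with the rest of compound 1 held constant, inhibition weakens beyond the scatter when the 4-methoxybenzyl group is cut back to ethyl. No measured evidence explains this change.

The compounds shown leave open whether the aromatic ring or the length of the group matters more at this place. A butyl chain or a cyclohexyl ring in the same position would help to separate the two.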